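Methoxy to Trifluoromethyl on the Aryl Piperazine

This account rests on a few compounds, and the source may have more. Where it says the series, first, only, none or still open, it means among the compounds named here.

Measured so far, in an assay on HEK293 cells for inhibition of Voltage-dependent T-type calcium channel subunit alpha-1G (Homo sapiens), read by fluorescence, tested at 10 uM; on this read-out higher numbers stand for more inhibition at the one concentration tested (going by the name of the read-out) and lower numbers for less inhibition:
- compound 1, `CCCc1nc(-c2ccccc2)c(CNCCCN2CCN(c3cccc(C(F)(F)F)c3)CC2)o1`: 51.6%
- compound 2, `CCCc1nc(-c2ccccc2)c(CNCCCN2CCN(c3cccc(OC)c3)CC2)o1`: 36.4%
- compound 3, `CCCc1nc(-c2ccccc2)c(CNCCN2CCN(c3ccc(OC)cc3)CC2)o1`: 51.5%

Compound 1 and compound 2 share a core and differ in one place only: trifluoromethyl in place of methoxy on an aromatic carbon. This change gave a number 15.2 percentage points higher from compound 2 to compound 1 (beyond the scatter). Compound 3 differs from compound 2 in more than one place; the difference between the two cores is not broken down here. In this assay compound 3 sits within the scatter of compound 1, and its value lies above that of compound 2 by more than the scatter.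

Compound 4, `CCCc1nc(-c2ccccc2)c(CNCCN2CCN(c3ccc(C(F)(F)F)cc3)CC2)o1`, has not yet been measured. It differs from compound 3 as follows: trifluoromethyl in place of methoxy on an aromatic carbon. This is the same kind of change as that from compound 2 to compound 1, but not the same: in the earlier pair the group stands meta to a large group, here it stands para to a large group.

Going by the values given here, the only measured step of this kind is the one from compound 2 to compound 1, and the expectation for compound 4 rests on it. From compound 3 to compound 4 a step of a number 10.5 percentage points higher from compound 3 to compound 4 (beyond the scatter) is expected, beside a number 15.2 percentage points higher from compound 2 to compound 1 (beyond the scatter) for the earlier pair. For compound 4 a value of 62% is estimated, with a range of 48% to 76% because the place differs and the step from compound 2 to compound 1 is only modest.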

Compound 4, a percentage reported as inhibition, at one concentration (the size of the read-out at that concentration, not a potency): 58.7%
The estimate for compound 4 lay 3.3 percentage points above the measured number; measured number inside the range.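

In this assay, trifluoromethyl in place of methoxy on an aromatic carbon, here para to a large group, gives a number 7.2 percentage points higher from compound 3 to compound 4 (within the scatter), so on this core the change cannot be told apart from the scatter of repeated measurements. Set beside the earlier pair, the two steps cannot be told apart either: the same change on two cores in this assay, a number 15.2 percentage points higher (beyond the scatter) from compound 2 to compound 1 and a number 7.2 percentage points higher (within the scatter) from compound 3 to compound 4, 8 percentage points apart, within the scatter of two such steps. Going by these compounds alone, this shows that the second core gives no evidence against carrying the change over, but it does not show that the gain seen on the first core is repeated on the second, and with only two pairs, whose cores differ in more than one place and whose groups stand in different places on the ring, it cannot separate any effect of the place from any effect of the core.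

Left open is how a nitrile or a chlorine on the same aromatic carbon would compare with methoxy and trifluoromethyl on either core, and whether a trifluoromethyl group and a methoxy group exchanged in the same place on both cores would give steps of like size. Also open, from the compounds shown here alone, is whether steps read at the one concentration of this assay would hold across a full concentration series.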